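Cyclopropyl substitution at the eight-position of the propyl xanthine core

This account rests on a few compounds, and the source may have more. Where it says the series, first, only, none or still open, it means among the compounds named here.

Working notes on the series. Going by the values given here, compound 1 `CCCn1c(=O)c2nc(C3CCCC(N)C3)[nH]c2n(CCC)c1=O` is the reference point; in a functional assay for antagonist activity at adenosine receptor A1 (Homo sapiens) (a lower number here means a stronger inhibitor, a higher number a weaker inhibitor), compound 1 gives 50 nM, the only full number in this set, with one further entry that is not a single number. Compound 2 `CCCn1c(=O)c2nc(C3CCCC3C(=O)N(C)CCN(C)C)[nH]c2n(CCC)c1=O` gives 53 nM; > 3000 nM (2 entries), several entries that do not agree with one another. Among the compounds with values here, those several entries, (the several entries of compound 2 in this assay, 53 nM; > 3000 nM (2 entries)), do not settle how strongly compound 2 acts, so no measured step is available to guide the next change.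

Compound 3 `CCCn1c(=O)c2nc(C3CC3C)[nH]c2n(CCC)c1=O` carries 2-methylcyclopropyl in place of 3-aminocyclohexyl on an aromatic carbon. The amine and its ring are gone, but a small carbocycle remains at the same aromatic carbon. The step from compound 1 to compound 3 is expected to be modest and, if anything, toward weaker inhibition, a 1.6-fold higher number from compound 1 to compound 3 (0.20 log units; within the scatter). Compound 3 is therefore estimated at 80 nM in this assay, within a range of 15 nM to 400 nM.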

Compound 3, inhibition constant: 11 nM
The estimate for compound 3 lay 7.3-fold (0.86 log units) above the measured number; the whole stated range lies above it.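

Replacing 3-aminocyclohexyl with 2-methylcyclopropyl gives, in this assay, a 4.5-fold lower number from compound 1 to compound 3 (0.66 log units; beyond the scatter). At this aromatic carbon, between two ring nitrogen atoms, neither the amine nor the six-membered ring is required for inhibition in this range, and the group with fewer heavy atoms and no hydrogen-bond donors or acceptors gives the lower number. Nothing measured in this set bears on why the number falls.

The step removes the amine and changes the ring size at once, so the share of each in the change remains unresolved. A plain cyclohexyl group would isolate the loss of the amine, while an unsubstituted cyclopropyl group would show what the methyl group contributes.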